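A few compounds are considered here, and "the series" means these few. Any claim that something is new, unique, unknown or untested is made for them only; others in the source may bear on it.

Measured compounds:
compound 1, `COc1ccc(F)cc1CNCCCNc1ccnc2cc(CC3CCCCC3)ccc12`: 9.47
compound 2, `COc1ccc(F)cc1CNCCCNc1ccnc2cc(CCc3ccccc3)ccc12`: 9.47
compound 3, `COc1cccc(CNCCCNc2ccnc3cc(CCc4ccccc4)ccc23)c1O`: 9.47

All three values come from a physicochemical assay for acid dissociation. The three compounds share a core and each pair differs in one place. Compound 1 differs from compound 2 by cyclohexyl in place of benzyl on a saturated chain carbon bound to an aromatic carbon; the step of no change at the digits printed from compound 2 to compound 1 (within the scatter). Compound 3 differs from compound 2 by 2-hydroxy-3-methoxyphenyl in place of 5-fluoro-2-methoxyphenyl on a saturated chain carbon bound to an amine nitrogen; the step of no change at the digits printed from compound 2 to compound 3 (within the scatter). Compound 3 therefore stands level with compound 1 and compound 2 in this assay, and neither change made so far has moved the read-out beyond the scatter.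

Compound 4, `COc1cccc(CNCCCNc2ccnc3cc(CC4CCCCC4)ccc23)c1O`, has not yet been measured in this assay. It differs from compound 3 by cyclohexyl in place of benzyl on a saturated chain carbon bound to an aromatic carbon. Among the compounds with values here, this is the same change, at the same place, as the one from compound 2 to compound 1, where the step was no change at the digits printed from compound 2 to compound 1 (within the scatter). The cores of compound 3 and compound 4 on one side and compound 2 and compound 1 on the other differ by 2-hydroxy-3-methoxyphenyl in place of 5-fluoro-2-methoxyphenyl on a saturated chain carbon bound to an amine nitrogen, and that difference itself gave no change at the digits printed from compound 2 to compound 3 (within the scatter).

The step expected from compound 3 to compound 4 in this assay is no change at the digits printed from compound 3 to compound 4 (within the scatter), and this expectation rests on the earlier step of no change at the digits printed from compound 2 to compound 1 (within the scatter), which was within the scatter. Within the data shown here, no measured step in this set falls outside the scatter, so the estimate is simply that compound 4 sits where compound 3 sits. Compound 4 is therefore estimated at 9.47, with a range from 9.2 to 9.75.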

Compound 4, acid dissociation constant: 9.47
Beside the measured number, compound 4's estimate shows no gap at the digits printed, within the range that was stated.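

In this assay, cyclohexyl in place of benzyl on a saturated chain carbon bound to an aromatic carbon gives no change at the digits printed from compound 3 to compound 4 (within the scatter) on the core carrying 2-hydroxy-3-methoxyphenyl, and the same change gives no change at the digits printed from compound 2 to compound 1 (within the scatter) on the core carrying 5-fluoro-2-methoxyphenyl, so across these two cores the change carries over as a null result. The other change reads the same way with either group in place, giving no change at the digits printed from compound 1 to compound 4 (within the scatter) alongside no change at the digits printed from compound 2 to compound 3 (within the scatter), which closes the four compounds into a square with every side within the scatter. Within the data shown here, this does not show that the change would stay silent on any further core or in any other read-out, and with no step here beyond the scatter, the set cannot test whether a change of real size would carry from one core to another.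

The compounds shown leave open whether the read-out would hold if an amine or a carboxylic acid entered in place of benzyl, or if a longer chain took the place of phenethyl. No supporting data at hand bear on the reason for this flat result.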